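This account rests on a few compounds, and the source may have more. Where it says the series, first, only, none or still open, it means among the compounds named here.

Measured so far:
- compound 1, `CC/C=C\CC1C(=O)C=CC1CC(=O)OC`: 19000 nM
- compound 2, `CC/C=C\C[C@H]1C(=O)C=C[C@H]1CC(=O)Oc1ccc(O)cc1`: 23000 nM
- compound 3, `CC/C=C\C[C@H]1C(=O)C=C[C@H]1CC(=O)Oc1ccccc1OC`: 32000 nM

All three share one core and differ only in the ester part. In a functional assay on RAW264.7 cells (Mus musculus) for inhibition, read by ELISA, with a stated time of 24 h (a higher number here means that more compound is needed for the effect, a lower number that less compound is needed), compound 1 gives 19000 nM, compound 2 gives 23000 nM and compound 3 gives 32000 nM. The number for compound 2 lies between those of compound 1 and compound 3, and each of those two neighbours is within the scatter of repeated measurements, so the three compounds cannot be separated on these data. Changing the ester group from methyl to either aryl variant leaves the read-out where it was.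

The next compound, compound 4, `CC/C=C\C[C@H]1C(=O)C=C[C@H]1CC(=O)OC(C)CC`, carries the change (sec-butyl in place of 4-hydroxyphenyl on an oxygen next to a carbonyl group). For the measured compounds named here, nothing measured so far shows that the ester part moves the read-out beyond the scatter, so no step in this assay beyond the scatter is expected in either direction for the step from compound 2 to compound 4, that is, a 1.2-fold lower number from compound 2 to compound 4 (0.06 log units; within the scatter). Compound 4 is therefore expected to give about 20000 nM in this assay, with a range from 8000 nM to 50000 nM.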

Compound 4, half-maximal effective concentration: 22000 nM
For compound 4 the middle estimate is 1.1-fold (0.04 log units) below the measured one; the measured number falls inside the stated range.
By their numbers in this assay, from the lowest: compounds 1, 4, 2 and 3 (each within the scatter of the next).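

For the compounds shown here, replacing 4-hydroxyphenyl by sec-butyl on an oxygen next to a carbonyl group gives a 1.0-fold lower number from compound 2 to compound 4 (0.02 log units; within the scatter) in this assay and is the only step at this position that can be read so far. The change removes the aromatic ring and the hydrogen-bond donor together and goes from 7 heavy atoms to 4, yet the step stays within the scatter, so neither the ring nor the donor is needed on this oxygen for the read-out seen in compound 2. No supporting measurement bears on why the read-out holds.

Whether any group on this oxygen can move the read-out beyond the scatter remains open, since the compounds shown include no carboxylic acid, amine or longer chain there. The effect of changes to the shared core also remains open, since all the compounds shown differ only in the ester part.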